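Pyridazine-free notes: phenoxy swap on compound 3

The source may report more compounds than this note shows. Statements on the series, on what has been measured and on what is new or still open speak of the compounds shown alone.

Working notes: phenoxy in place of 4-methylpiperazin-1-yl

Measured in an ADME assay on cells (Fibroblast, Homo sapiens) for antiproliferative activity, with a stated time of 48 h; a lower number here means a stronger inhibitor, a higher number a weaker inhibitor:
- Compound 1 `CCN(CC)c1ccc(-c2cccc(OC)c2)nn1`: > 25000 nM (a limit)
- Compound 2 `COc1ccccc1-c1ccc(N2CCN(C)CC2)nn1`: > 25000 nM (a limit)
- Compound 3 `CN1CCN(c2ccc(-c3cccc(C(F)(F)F)c3)nn2)CC1`: > 25000 nM (a limit)

Compound 3 gives > 25000 nM, which is a limit of the assay and not a number. It has no numerical position in the series, as the only measured mark is the limit of > 25000 nM in this assay, at which 3 of the 3 values shown sit.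

The next compound is compound 4 `FC(F)(F)c1cccc(-c2ccc(Oc3ccccc3)nn2)c1`, with phenoxy in place of 4-methylpiperazin-1-yl on an aromatic carbon of the shared core (phenoxy in place of 4-methylpiperazin-1-yl on an aromatic carbon). Going by the values given here, no measured pair differs in one place, so the series gives no direct precedent for this change. Among the compounds with values here, with the limit of > 25000 nM in this assay, at which 3 of the 3 values shown sit, as the only guide, no change beyond the scatter is expected in this assay, and the expected step is a number no higher from compound 3 to compound 4 (the limit leaves the size open). A reading at the same limit is the likeliest outcome, although a measurable value cannot be excluded. The estimate for compound 4 is 25000 nM, with an expected range of 10000 nM to 40000 nM.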

Compound 4, half-maximal inhibitory concentration: > 25000 nM
Compound 4: only a limit was reported; the forecaster's own chance of this, stated with the estimate: 75%; the middle value lies on the limit itself.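

In this assay compound 4 gives > 25000 nM, a limit of the assay and not a number. No step can be read from compound 3 to compound 4, as both values are limits: the limit of > 25000 nM in this assay, at which 4 of the 4 values shown sit.

The compounds shown leave open which change to the shared core, if any, would give a measurable value in this assay.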